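Swapping the para halogen on the sulfonyl ring

This account rests on a few compounds, and the source may have more. Where it says the series, first, only, none or still open, it means among the compounds named here.

Of the compounds shown here, three sharing one core have been tested in a functional assay on SMMC-7721 cells (Homo sapiens) for cytotoxicity, read by MTT assay, with a stated time of 24 h; on this read-out higher numbers stand for weaker inhibition and lower numbers for stronger inhibition. Compound 1 `Cc1ccc(S(=O)(=O)N2C/C(=C\c3ccc(F)cc3)C(=O)/C(=C/c3ccc(F)cc3)C2)cc1` gives 5000 nM. Compound 2 `O=C1/C(=C/c2ccc(F)cc2)CN(S(=O)(=O)c2ccc(O[N+](=O)[O-])cc2)C/C1=C\c1ccc(F)cc1` gives 5000 nM. Compound 3 `O=C1/C(=C/c2ccc(F)cc2)CN(S(=O)(=O)c2ccc(F)cc2)C/C1=C\c1ccc(F)cc1` gives 14700 nM, the highest of the three numbers, so it stands as the weakest inhibitor shown: the steps of a 2.9-fold higher number from compound 1 to compound 3 (0.47 log units; beyond the scatter) and a 2.9-fold higher number from compound 2 to compound 3 (0.47 log units; beyond the scatter) both lie beyond the scatter.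

Compound 4 `O=C1/C(=C/c2ccc(F)cc2)CN(S(=O)(=O)c2ccc(Br)cc2)C/C1=C\c1ccc(F)cc1` differs from compound 3 in one place. bromo in place of fluoro on an aromatic carbon The two measured steps that reach compound 3 both show that changing the group on this aromatic carbon, para to a large group, moved the number; in each case the other group gave a lower number than fluoro. Bromo has not been tried, but on that evidence a modest drop, or at most no change beyond the scatter, is expected for compound 4: the step of a 2.1-fold lower number from compound 3 to compound 4 (0.32 log units; beyond the scatter) is the estimate. In this assay compound 4 is expected to give 7000 nM, within 3000 nM to 15000 nM.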

Compound 4, half-maximal inhibitory concentration: 11500 nM
For compound 4 the middle estimate is 1.6-fold (0.22 log units) below the measured one, and the stated range covers the measured number.
By their numbers in this assay, from the lowest: compounds 1 and 2 (each within the scatter of the next); then compounds 4 and 3 (each within the scatter of the next).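

Putting bromo where fluoro stood gives a 1.3-fold lower number from compound 3 to compound 4 (0.11 log units; within the scatter) in this assay and so, on this aromatic carbon, para to a large group, the two halogens cannot be told apart. Bromo still stands apart from the other two groups, with a 2.3-fold higher number from compound 2 to compound 4 (0.36 log units; beyond the scatter) and a 2.3-fold higher number from compound 1 to compound 4 (0.36 log units; beyond the scatter) as the steps, so the four compounds fall into two pairs: fluoro and bromo give the higher numbers, while methyl and nitrooxy give the lower numbers. Nothing shown here offers a reason for this split.

Chloro would show whether the halogen pair extends to a third halogen, while an amine, a carboxylic acid or a methoxy group on the same carbon would show whether the split holds beyond these four groups. The compounds also leave open whether these swaps would behave alike with something other than the two 4-fluorophenyl groups on the shared core.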